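The source may hold more compounds than are shown below. What is called first, only, known or untested is meant among the compounds shown, and "the series" means these compounds.

Measured compounds in a functional assay for inhibition of sodium/hydrogen exchanger (Oryctolagus cuniculus); on this read-out higher numbers stand for weaker inhibition and lower numbers for stronger inhibition:
- compound 1 `Cc1cc(Cl)c(S(C)(=O)=O)cc1C(=O)N=C(N)N` gives 25 nM
- compound 2 `Cc1cc(OCc2ccccc2)c(S(C)(=O)=O)cc1C(=O)N=C(N)N` gives 28 nM
- compound 3 `Cc1cc(N2CCCCC2)c(S(C)(=O)=O)cc1C(=O)N=C(N)N` gives 21 nM

Compound 3 has the lowest of the three numbers, but its steps to compound 1 and compound 2 both lie within the scatter, so no ranking among the three is drawn. Compound 4 `Cc1cc(Nc2ncccn2)c(S(C)(=O)=O)cc1C(=O)N=C(N)N` differs from compound 3 by (pyrimidin-2-yl)amino in place of piperidin-1-yl on an aromatic carbon. Within the data shown here, the steps that bear on this are those at the same aromatic carbon: a 1.2-fold lower number from compound 1 to compound 3 (0.08 log units; within the scatter), a 1.3-fold lower number from compound 2 to compound 3 (0.12 log units; within the scatter) and a 1.1-fold higher number from compound 1 to compound 2 (0.05 log units; within the scatter), every one within the scatter. Three quite different groups at this carbon leave the number essentially unchanged, so for compound 4 no step beyond the scatter is expected: a 1.3-fold higher number from compound 3 to compound 4 (0.12 log units; within the scatter). Compound 4 is estimated at 28 nM, with a range of 12 nM to 70 nM.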

Compound 4, half-maximal inhibitory concentration: 8.3 nM
Compound 4: the middle estimate sits 3.4-fold (0.53 log units) above what was measured, and the stated range ends above it.
By their numbers in this assay, from the lowest: compound 4; then compounds 3, 1 and 2 (each within the scatter of the next).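

In this assay this aromatic carbon, ortho to a methylsulfonyl group, is not indifferent to what it carries: (pyrimidin-2-yl)amino gives a 2.5-fold lower number from compound 3 to compound 4 (0.40 log units; beyond the scatter) as well as a 3.0-fold lower number from compound 1 to compound 4 (0.48 log units; beyond the scatter) and a 3.4-fold lower number from compound 2 to compound 4 (0.53 log units; beyond the scatter) with all three steps modest yet beyond the scatter. Chloro, benzyloxy and piperidin-1-yl stay within the scatter of one another, so among these four compounds only (pyrimidin-2-yl)amino stands apart. No evidence on hand accounts for this step.

Which part of the entering group carries the step stays open: phenylamino, or pyrimidin-2-yl joined through oxygen, would separate the ring nitrogens from the amine hydrogen.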